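Adding a Pyridinylmethyl Group: Cytotoxicity Expected to Stay Low

A few compounds are considered here, and "the series" means these few. Any claim that something is new, unique, unknown or untested is made for them only; others in the source may bear on it.

Measured so far in an ADME assay on MDBK cells (Bos taurus) for cytotoxicity; on this read-out lower numbers stand for higher toxicity in this test and higher numbers for lower toxicity in this test:
Compound 1, `Cc1ccccc1Cn1ccc2nc(-c3ccccc3)nc-2c1`: > 100000 nM, a limit of the assay.
Compound 2, `Brc1cccc(Cn2ccc3nc(-c4ccccc4)nc-3c2)c1`: 85000 nM.
Compound 3, `c1ccc(-c2nc3cc[nH]cc-3n2)cc1`: > 100000 nM, a limit of the assay.

Compound 3 therefore has no exact number in this assay, only the limit at which it sits. The same holds for compound 1, and the limit of > 100000 nM in this assay, at which 2 of the 3 values shown sit, marks the position shared by these two compounds. Compound 2 gives a real number that lies close to that limit. Going by the values given here, the only measured step, an at least 1.1-fold lower number from compound 1 to compound 2 (0.07 log units; that floor lies within the scatter), is a swap of one aromatic group for another on the carbon attached to the ring nitrogen, and it stays within the scatter.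

Compound 4, `c1ccc(-c2nc3ccn(Cc4cccnc4)cc-3n2)cc1`, differs from compound 3 by (pyridin-3-yl)methyl in place of hydrogen on an aromatic nitrogen. This attaches a new group to the nitrogen that carries only a hydrogen in compound 3, while compounds 1 and 2 already carry a group on that nitrogen and still show little or no toxicity. The change from compound 3 to compound 4 is thus expected to produce no step beyond the scatter, with compound 4 most likely again at the limit.

Compound 4 is expected to give 100000 nM, within a range from 50000 nM to 200000 nM. The expected step of a number no higher from compound 3 to compound 4 (the limit leaves the size open) is therefore essentially none.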

Compound 4, half-maximal cytotoxic concentration: > 100000 nM
Compound 4: a limit, no number (the forecaster's own chance of this, stated with the estimate: 60%); the middle value lies on the limit itself.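

In this assay compound 4 also sits at a limit of the assay, so a (pyridin-3-yl)methyl group on this aromatic nitrogen, a group whose six-membered aromatic ring holds a nitrogen, gives no sign of more toxicity than the hydrogen of compound 3. Going by these compounds alone, the steps to compound 3 and to compound 1 cannot be read, since both ends of each are limits, and the one readable step is an at least 1.1-fold higher number from compound 2 to compound 4 (0.07 log units; that floor lies within the scatter) and so shows no real difference between the pyridin-3-yl and 3-bromophenyl groups on this chain carbon. Across the compounds shown, the hydrogen and all three groups on this nitrogen leave the read-out at or close to the same place, with the limit now shared more widely: the limit of > 100000 nM in this assay, at which 3 of the 4 values shown sit.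

Going by these compounds, whether an amine or a carboxylic acid on the aromatic ring, or a longer chain in place of the single carbon, would bring a clear drop in the number stays open. The exact numbers of compounds 1, 3 and 4 also remain unknown, so any order among these three is open too.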